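Amino Substitution and Vero Cell Cytotoxicity

This account rests on a few compounds, and the source may have more. Where it says the series, first, only, none or still open, it means among the compounds named here.

Measured compounds:
compound 1, `Oc1ccc(-c2nc3cc(C(F)(F)F)ccc3[nH]2)cc1`, > 100000 nM
compound 2, `COc1ccc(-c2nc3cc(C(F)(F)F)ccc3[nH]2)cc1`, 15000 nM
compound 3, `O=C(CCl)Nc1ccc(-c2nc3cc(C(F)(F)F)ccc3[nH]2)cc1`, 35000 nM

In an ADME assay on Vero cells (Chlorocebus sabaeus) for cytotoxicity (on this read-out higher numbers stand for lower toxicity in this test and lower numbers for higher toxicity in this test), compound 2 gives 15000 nM. In this assay compound 3 gives 35000 nM. Compound 1 gives > 100000 nM in this assay, which is a limit of the assay and not a number (the limit of > 100000 nM in this assay, at which 1 of the 3 values shown sits). Compound 2 thus stands with the lowest of the two numbers shown; its nearest neighbour is reached by the step of a 2.3-fold higher number from compound 2 to compound 3 (0.37 log units; beyond the scatter). The other measured steps are an at least 6.6-fold lower number from compound 1 to compound 2 (0.82 log units; beyond the scatter) and an at least 2.8-fold lower number from compound 1 to compound 3 (0.45 log units; beyond the scatter).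

Compound 4 is `COc1ccc(-c2nc3cc(C(F)(F)F)ccc3[nH]2)c(N)c1`. The change from compound 2 is amino in place of hydrogen on an aromatic carbon. For the measured compounds named here, none of the measured steps exchanges a hydrogen for an amino group; each of them alters the oxygen-bearing position instead, so none bears directly on this change. Without a matching step, the expectation is a step that stays within the scatter, in either direction, a 1.3-fold higher number from compound 2 to compound 4 (0.12 log units; within the scatter). Compound 4 is therefore expected to give about 20000 nM in this assay, within a range from 7000 nM to 60000 nM.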

Compound 4, half-maximal cytotoxic concentration: 50000 nM
For compound 4 the middle estimate is 2.5-fold (0.40 log units) below the measured one; low and high end bracket the measured number.
By their numbers in this assay, from the lowest: compound 2; then compounds 3 and 4 (each within the scatter of the next). At a limit, above all of these: compound 1.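

In this assay, the aromatic carbon ortho to a large group and meta to a methoxy group proves sensitive to substitution, with amino in place of hydrogen giving a 3.3-fold higher number from compound 2 to compound 4 (0.52 log units; beyond the scatter). This is the first step shown that leaves the oxygen-bearing position untouched, and it points towards lower toxicity in this test for the amino-bearing compound. Compound 1 remains the only compound at a limit, which is a limit of the assay and not a number: the limit of > 100000 nM in this assay, at which 1 of the 4 values shown sits.

The compounds shown leave open whether a methyl group, a carboxylic acid or a longer amine chain on this same carbon would shift the number in the same direction. They also leave open whether an amino group here would do the same in compound 1 or compound 3, which carry other groups in place of methoxy.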